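The source may report more compounds than this note shows. Statements on the series, on what has been measured and on what is new or still open speak of the compounds shown alone.

Measured compounds in a functional assay on HepG2 cells (Homo sapiens) for cytotoxicity, read by MTT assay, with a stated time of 72 h; on this read-out higher numbers stand for weaker inhibition and lower numbers for stronger inhibition: compound 1 `COc1ccc2ccc(=O)oc2c1C1=NN(C(C)=O)C(c2cccs2)C1` gives 75 nM; compound 2 `COc1ccc2ccc(=O)oc2c1C1=NN(c2ccccc2)C(c2ccc(SC)cc2)C1` gives 78 nM; compound 3 `COc1ccc2ccc(=O)oc2c1C1=NN(C(C)=O)C(c2ccccc2)C1` gives 52 nM.

Compound 3 gives the lowest of the three numbers, but its distance to compound 1 and to compound 2 is within the scatter, so no order among the three can be read. Compound 4 `COc1ccc2ccc(=O)oc2c1C1=NN(c2ccccc2)C(c2ccccc2)C1` differs from compound 3 by phenyl in place of acetyl on an amine nitrogen in a ring. Among the measured compounds shown here, no measured step changes only the group on this ring nitrogen. For the measured compounds named here, the one single-change step, a 1.4-fold lower number from compound 1 to compound 3 (0.16 log units; within the scatter), concerns the other ring carbon and was within the scatter. Compound 2, which carries a phenyl on the ring nitrogen together with a different aryl group, sits within the scatter of compound 3. No step beyond the scatter is therefore expected in this assay; the expected step is a 1.2-fold higher number from compound 3 to compound 4 (0.06 log units; within the scatter). Compound 4 is estimated at 60 nM, within 25 nM to 150 nM.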

Compound 4, half-maximal inhibitory concentration: 73 nM
Beside the measured number, compound 4's estimate is 1.2-fold (0.09 log units) below it, and the stated range covers the measured number.
By their numbers in this assay, from the lowest: compounds 3, 4, 1 and 2 (each within the scatter of the next).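

In this assay the change on the amine nitrogen in a ring can now be read alone: a 1.4-fold higher number from compound 3 to compound 4 (0.15 log units; within the scatter) shows no separation of acetyl and phenyl at this place, even though phenyl enters as a six-membered aromatic ring and the hydrogen-bond acceptor of acetyl leaves. Methylsulfanyl on the aromatic carbon also shows no separable effect, with a 1.1-fold lower number from compound 2 to compound 4 (0.03 log units; within the scatter) as the step. No measurement available here bears on these results.

Open, going by these compounds, is whether a hydrogen, a longer acyl chain or a benzoyl group on this nitrogen would give a step beyond the scatter. Also open, on these data alone, is whether an amine or a carboxylic acid on the entering phenyl would do so.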